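The source may report more compounds than this note shows. Statements on the series, on what has been measured and on what is new or still open speak of the compounds shown alone.

Compound 1 `Cn1cnc(CS(=O)(=O)c2ccc(Br)cc2)c1[N+](=O)[O-]` and compound 2 `Cn1cnc(CS(=O)(=O)c2ccc(F)cc2)c1[N+](=O)[O-]` share one core, while compound 3 `Cc1nc(CS(=O)(=O)c2ccc(Br)cc2)c([N+](=O)[O-])n1CCO` and the still unmeasured compound 4 `Cc1nc(CS(=O)(=O)c2ccc(F)cc2)c([N+](=O)[O-])n1CCO` share another; the difference between the two cores is not broken down here. In an ADME assay on THP-1 cells (Homo sapiens) for cytotoxicity, read by flow cytometry and propidium iodide staining, with a stated time of 72 h (a higher number here means a weaker inhibitor, a lower number a stronger inhibitor), compound 1 gives only a limit, > 694000 nM. Compound 2 also gives only a limit in this assay, > 835000 nM. Compound 3 gives a number in this assay, 124000 nM. Within the first pair the change fluoro in place of bromo on an aromatic carbon makes a step that the two limits leave unreadable from compound 1 to compound 2, which cannot be read because of the limit of > 694000 nM in this assay, at which 1 of the 3 values shown sits, and (the limit of > 835000 nM in this assay, at which 1 of the 3 values shown sits). Compound 4 carries the same change against compound 3, (fluoro in place of bromo on an aromatic carbon). For compound 4 a small step of a 1.6-fold higher number from compound 3 to compound 4 (0.21 log units; within the scatter) is expected, since the measured pair gives no readable size. Compound 4 is therefore estimated at 200000 nM, between 70000 nM and 600000 nM.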

Compound 4, half-maximal inhibitory concentration: > 728000 nM
Compound 4: a limit, no number; the forecaster's own chance of this, stated with the estimate: 30%; at least 3.6-fold (0.56 log units) between middle value and limit.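

In this assay, fluoro in place of bromo on an aromatic carbon gives an at least 5.8-fold higher number from compound 3 to compound 4 (0.76 log units; beyond the scatter). Going by these compounds, compound 4 gives only a limit, > 728000 nM, so the true size of this step remains unknown and could be larger. The same change on the core of compound 1 cannot be read, as compound 1 and compound 2 both give only limits, so the series neither confirms nor refutes that the change carries the same size from one core to the other.

Still open, on these data alone, is where a chloro or a nitrile at the same place on the aromatic ring would fall in this assay. Also open, as far as these compounds go, is whether an amine there would yield a number rather than a limit.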